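Trifluoromethyl on the aryl ring of a succinimide-piperazine amide

The source may hold more compounds than are shown below. What is called first, only, known or untested is meant among the compounds shown, and "the series" means these compounds.

Two members of this series have been run in a functional assay on the whole organism (strain Swiss) with Mus musculus as the target, in the maximal electroshock model, with a stated time of 0.5 h, at a dose of 100 mg/kg by the intraperitoneal route; a higher number here means a stronger effect of the compound at the dose given, a lower number a weaker effect. Compound 1 `COCC(C(=O)N1CCN(c2cccc(C(F)(F)F)c2)CC1)N1C(=O)CCC1=O` gives 75% in this assay. Compound 2 `CC(C(=O)N1CCN(c2ccccc2)CC1)N1C(=O)CCC1=O` gives 0% in this assay. Compound 2 thus stands lowest of the two numbers; its nearest neighbour is compound 1, whose number is higher by a gap beyond the scatter. For the measured compounds named here, no step between compounds that differ in one place is available, so the two values can only be set side by side.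

Compound 3 `CC(C(=O)N1CCN(c2cccc(C(F)(F)F)c2)CC1)N1C(=O)CCC1=O` has not yet been measured in this assay. It differs from compound 2 in one place: trifluoromethyl in place of hydrogen on an aromatic carbon. Going by the values given here, compound 1 carries the same trifluoromethyl on the same ring, and differs from compound 3 only elsewhere; no counted step links those two, so their values are simply compared.

A rise beyond the scatter is expected from compound 2 to compound 3, a number 50 percentage points higher from compound 2 to compound 3 (beyond the scatter), because compound 1 gives 75%. Compound 3 is therefore estimated at 50% in this assay, within a range of 10% to 90%; with only two measured points the range is kept wide.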

Compound 3, a percentage reported as activity, at one dose (the size of the read-out at that dose, not a potency): 75%
Estimate against measurement, compound 3: 25 percentage points below; the measured number falls inside the stated range.
By their numbers in this assay, from the lowest: compound 2; then compounds 1 and 3 (each within the scatter of the next).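

In this assay, for the compounds shown here, the single change of trifluoromethyl in place of hydrogen on an aromatic carbon, meta to a large group, gives a number 75 percentage points higher from compound 2 to compound 3 (beyond the scatter), so this aromatic position decides between no read-out and a clear one in this matched pair. Hydrogen in place of methoxy on the saturated chain carbon gives no change at the digits printed from compound 1 to compound 3 (within the scatter), so with trifluoromethyl on the ring, this chain change leaves the read-out at this dose within the scatter, which the side-by-side values of the first two compounds could not show. No measurement on hand bears on the origin of either step.

Open, from the compounds shown here alone, is whether a different group on the same aromatic carbon, such as chlorine, a nitrile or a methoxy group, would match trifluoromethyl, and whether the read-out at this single dose conceals a difference in potency between compound 1 and compound 3. Also open, going by these compounds, is whether the saturated chain carbon would accept a longer chain or an amine, and whether any change there could restore a read-out without trifluoromethyl on the ring.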